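The source may hold more compounds than are shown below. What is called first, only, known or untested is meant among the compounds shown, and "the series" means these compounds.

Measured so far:
- compound 1, `COc1cc(-c2cc(C(=O)O)c3ccccc3n2)ccc1OCC(=O)Nc1ccc(C)cc1`: > 300000 nM
- compound 2, `COc1cc(-c2cc(C(=O)O)c3ccccc3n2)ccc1OCC(=O)Nc1ccc(F)cc1`: 286000 nM

In an ADME assay on HaCaT cells (Homo sapiens) for inhibition (on this read-out higher numbers stand for weaker inhibition and lower numbers for stronger inhibition), compound 1 returns no number but a limit of the assay, > 300000 nM. In this assay, for the measured compounds named here, compound 2 gives 286000 nM, which is the only true number. Going by the values given here, the single measured step, an at least 1.0-fold lower number from compound 1 to compound 2 (0.02 log units; that floor lies within the scatter), stays within the scatter, and the limit of > 300000 nM in this assay, at which 1 of the 2 values shown sits, shows that one of the two entries sits at the limit of the assay, so the series sits at the weak edge of what this assay resolves.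

Compound 3, `COc1cc(-c2cc(C(=O)O)c3ccccc3n2)ccc1OCC(=O)NCc1ccco1`, differs from compound 2 by (furan-2-yl)methyl in place of 4-fluorophenyl on an amide-type nitrogen. Among the compounds with values here, no measured step covers this change; the one step available, an at least 1.0-fold lower number from compound 1 to compound 2 (0.02 log units; that floor lies within the scatter), concerns a different place and is itself within the scatter, so it gives no direction for an amide-nitrogen substituent swap. With compound 2 at the weak edge of the assay, the step from compound 2 to compound 3 is expected to stay within the scatter, a 1.0-fold lower number from compound 2 to compound 3 (0.01 log units; within the scatter). For compound 3 the expected value in this assay is therefore 280000 nM, with a range from 130000 nM to 600000 nM, and a fair chance that only a limit is reported.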

Compound 3, half-maximal inhibitory concentration: > 300000 nM
Compound 3 was reported as a limit; the forecaster's own chance of this, stated with the estimate: 45%; middle value at least 1.0-fold (0.02 log units) away from the limit.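

The change at the amide-type nitrogen, (furan-2-yl)methyl in place of 4-fluorophenyl, adds a second place of variation to the aromatic-carbon swap seen earlier, and its step reads an at least 1.0-fold higher number from compound 2 to compound 3 (0.02 log units; that floor lies within the scatter). In this assay compound 3 also gives only a limit of the assay, > 300000 nM, so swapping the six-membered carbon ring for a five-membered ring with one hetero atom, on a methyl link, yields no readable gain in inhibition at this place. The step from compound 1 to compound 3 cannot be read, and the series remains at the weak edge of the read-out: the limit of > 300000 nM in this assay, at which 2 of the 3 values shown sit.

Going by these compounds, with a single true number among the three compounds, no order can be stated, and the size of any effect at the amide-type nitrogen remains unknown. On these data alone, it stays open whether a morpholine or a longer aminoalkyl chain on that nitrogen, or an ester or primary amide in place of the carboxylic acid on the shared core, would give a number clearly separated from this limit.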